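The compounds below may be only part of what the source reports. "The series", "measured", "known", "first", "only" and "open" are said of these compounds alone.

Measured compounds in the series:
- compound 1, `CNc1nc2cc(Cl)c(Cl)cc2n1COCCO`; in a functional assay on KB cells (Homo sapiens) for inhibition (a lower number here means a stronger inhibitor, a higher number a weaker inhibitor), compound 1 gives > 100000 nM, a limit of the assay and not a number.
- compound 2, `CN(C)c1nc2cc(Cl)c(Cl)cc2n1COCCO`; in this assay compound 2 gives > 100000 nM, again a limit of the assay and not a number.

Going by the values given here, compound 2 therefore stands only at a limit; the one further value shown is also a limit, so no order between the two can be read. The step that the two limits leave unreadable from compound 1 to compound 2 is unreadable, since both ends sit at the limit of > 100000 nM in this assay, at which 2 of the 2 values shown sit.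

Compound 3, `OCCOCn1c(SCc2ccccc2)nc2cc(Cl)c(Cl)cc21`, is not yet measured. It differs from compound 2 by benzylsulfanyl in place of dimethylamino on an aromatic carbon. Among the compounds with values here, no measured step involves this change, and the only step available gives no size at all. Nothing in the numbers shown anchors an expectation beyond the limit itself. The estimate for compound 3 in this assay is therefore 60000 nM, between 5000 nM and 300000 nM, with a fair chance of another limit. The expected step of an at least 1.6-fold lower number from compound 2 to compound 3 (0.22 log units; that floor lies within the scatter) reflects this uncertainty rather than any trend.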

Compound 3, half-maximal inhibitory concentration: 55000 nM
Compound 3: the middle estimate sits 1.1-fold (0.04 log units) above what was measured, within the range that was stated.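

At the aromatic carbon between two ring nitrogen atoms, benzylsulfanyl gives compound 3 the first value in this assay that is a number and not a limit, whereas the dimethylamino and methylamino compounds mark only the edge of the assay: the limit of > 100000 nM in this assay, at which 2 of the 3 values shown sit.

Benzylsulfanyl in place of dimethylamino gives an at least 1.8-fold lower number from compound 2 to compound 3 (0.25 log units; that floor lies within the scatter), and in place of methylamino it gives an at least 1.8-fold lower number from compound 1 to compound 3 (0.25 log units; that floor lies within the scatter). Going by these compounds, both steps are floors, and since each floor lies within the scatter, the true size of the change stays unknown and no real gain is established.

Open, on these data alone, is whether the sulfur or the benzyl ring of benzylsulfanyl matters at this carbon, a question for methylsulfanyl and benzylamino. Also open, as far as these compounds go, is how a longer chain in place of the (2-hydroxyethoxy)methyl group would read with benzylsulfanyl in place.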